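The source may report more compounds than this note shows. Statements on the series, on what has been measured and on what is new or still open speak of the compounds shown alone.

Going by the values given here, compound 2 `CNC(=O)NCc1nc(-c2ccc(OC)cc2)c(-c2ccc(OC)cc2)s1` gives 22 nM in a functional assay with Oryctolagus cuniculus as the target (on this read-out higher numbers stand for weaker inhibition and lower numbers for stronger inhibition), the lowest of the two numbers known, while compound 1 `COc1ccc(-c2nc(CNC(=O)c3cccnc3)sc2-c2ccc(OC)cc2)cc1` gives 25 nM; the step of a 1.1-fold lower number from compound 1 to compound 2 (0.06 log units; within the scatter) lies within the scatter. Compound 3 `COc1ccc(-c2nc(/C=C/C(=O)O)sc2-c2ccc(OC)cc2)cc1` carries 2-carboxyethenyl in place of ((methylcarbamoyl)amino)methyl on an aromatic carbon. Among the compounds with values here, the only measured step swaps groups on a carbonyl carbon and says little about removing the whole ((methylcarbamoyl)amino)methyl group for a 2-carboxyethenyl group, so the step of a 9.1-fold higher number from compound 2 to compound 3 (0.96 log units; beyond the scatter) is expected with wide uncertainty and a likely weakening. Compound 3 is estimated at 200 nM, between 40 nM and 1500 nM.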

Compound 3, half-maximal inhibitory concentration: > 100 nM
Compound 3 gave a limit, no number; the forecaster's own chance of this, stated with the estimate: 10%; the middle value is on the limit's open side.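

In this assay compound 3 gives a limit, not a number: the limit of > 100 nM in this assay, at which 1 of the 3 values shown sits. Even so, this aromatic carbon, next to the ring nitrogen and the ring sulfur, proves sensitive to replacing the whole side chain, which the carbonyl-carbon swap between the earlier compounds could not show: the change to 2-carboxyethenyl gives an at least 4.5-fold higher number from compound 2 to compound 3 (0.65 log units; beyond the scatter) and an at least 4.0-fold higher number from compound 1 to compound 3 (0.60 log units; beyond the scatter). Both steps point to weaker inhibition. As far as these compounds go, how far compound 3 lies beyond its limit stays open, as does whether the carboxylic acid or the double bond matters more; a saturated chain ending in a carboxylic acid, or a methyl ester, would separate them.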